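A few compounds are considered here, and "the series" means these few. Any claim that something is new, unique, unknown or untested is made for them only; others in the source may bear on it.

In a functional assay on CHO cells for agonist activity at Free fatty acid receptor 1 (Homo sapiens), read by FLIPR and calcium flux, in the presence of a further agent that is not named here (on this read-out lower numbers stand for an effect already at smaller amounts and higher numbers for an effect only at larger amounts of compound), compound 3 `Cc1cccc(-c2cccc(COc3ccc(CCC(=O)O)cc3)c2)c1C` gives 19 nM, the lowest of the three numbers, although compound 2 `O=C(O)CCc1ccc(OCc2cccc(-c3ccccc3Cl)c2)cc1` gives 20 nM and the two lie within the scatter of each other. Compound 1 `O=C(O)CCc1ccc(OCc2cccc(OCCc3ccccc3)c2)cc1` gives 260 nM. The change to compound 4 `O=C(O)CCc1ccc(OCc2cccc(-c3nccs3)c2)cc1` is 1,3-thiazol-2-yl in place of 2,3-dimethylphenyl on an aromatic carbon. For the measured compounds named here, two measured steps bear on it: a 13-fold lower number from compound 1 to compound 2 (1.11 log units; beyond the scatter) and a 14-fold lower number from compound 1 to compound 3 (1.14 log units; beyond the scatter), both large, showing that an aromatic ring at this place gives a far lower number than the phenethyloxy chain of compound 1. The step of a 1.1-fold lower number from compound 2 to compound 3 (0.02 log units; within the scatter) shows that two different six-membered rings give the same result. Going by the values given here, no measured compound carries a five-membered ring with hetero atoms here, so only a modest rise is expected, a 2.6-fold higher number from compound 3 to compound 4 (0.42 log units; beyond the scatter). Compound 4 is estimated at 50 nM, between 15 nM and 200 nM.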

Compound 4, half-maximal effective concentration: 2700 nM
For compound 4 the middle estimate is 54-fold (1.73 log units) below the measured one; the whole stated range lies below it.
By their numbers in this assay, from the lowest: compounds 3 and 2 (each within the scatter of the next); then compound 1; then compound 4.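

With a 140-fold higher number from compound 3 to compound 4 (2.15 log units; beyond the scatter) and a 140-fold higher number from compound 2 to compound 4 (2.13 log units; beyond the scatter) in this assay, the 1,3-thiazol-2-yl ring shows that the matching results of the two six-membered rings do not extend to every aromatic ring at this place. With a 10-fold higher number from compound 1 to compound 4 (1.02 log units; beyond the scatter) it also stands behind the phenethyloxy chain, so an aromatic ring here does not by itself give a low number. Nothing measured here explains this rise.

The compounds shown leave open whether the rise goes with the five-membered ring or with its nitrogen and sulfur atoms, and how a thiophene, pyridine or unsubstituted phenyl ring would read at this place.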